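The source may hold more compounds than are shown below. What is called first, only, known or untested is meant among the compounds shown, and "the series" means these compounds.

Series notes, working document.

The series shares one core; compound 1 `CCNC(=O)c1noc(-c2cc(C(C)C)c(O)cc2O)c1-c1cc(COCC(N)=O)no1` and compound 2 `CCNC(=O)c1noc(-c2cc(C(C)C)c(O)cc2O)c1-c1cc(CN(CC)CC)no1` differ from compound 3 `CCNC(=O)c1noc(-c2cc(C(C)C)c(O)cc2O)c1-c1cc(C(=O)O)no1` only in the group attached to the same aromatic carbon of that core. In a functional assay on A2780 cells (Homo sapiens) for inhibition (a lower number here means a stronger inhibitor, a higher number a weaker inhibitor), compound 2 gives 78 nM. For compound 1 the result in this assay is "not determined" (no result reported), so no number is known for it. Among the measured compounds shown here, compound 3 gives 20000 nM in this assay, the highest of the two numbers available, and the one measured step in the set, a 260-fold higher number from compound 2 to compound 3 (2.41 log units; beyond the scatter), reaches it from the nearest neighbour, compound 2.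

Compound 4 `CCNC(=O)c1noc(-c2cc(C(C)C)c(O)cc2O)c1-c1cnn(C)c1` is the next entry, not yet measured. Relative to compound 3 the change is 1-methyl-1H-pyrazol-4-yl in place of 3-carboxy-1,2-oxazol-5-yl on an aromatic carbon. For the measured compounds named here, the only step that bears on this is the one from compound 2 to compound 3, which removed the (diethylamino)methyl group and put in the carboxy group; in compound 4 the carboxy group is gone again together with its ring. Going by the values given here, a large step in the opposite direction is therefore expected, a 50-fold lower number from compound 3 to compound 4 (1.70 log units; beyond the scatter), though the pyrazole has no direct precedent here and the recovery may fall short of compound 2. The expected value for compound 4 in this assay is 400 nM, in the range 60 nM to 3000 nM.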

Compound 4, half-maximal inhibitory concentration: 20 nM
Estimate against measurement, compound 4: 20-fold (1.30 log units) above, outside the stated range (below it).
By their numbers in this assay, from the lowest: compound 4; then compound 2; then compound 3.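

In this assay the change to 1-methyl-1H-pyrazol-4-yl on this aromatic carbon gives a 1000-fold lower number from compound 3 to compound 4 (3.00 log units; beyond the scatter) and so shows that the position accepts a different five-membered aromatic ring, not only a different group on the 1,2-oxazole. Compound 2 gives 78 nM and compound 4 gives 20 nM in this assay so the lowest number in the set comes without the (diethylamino)methyl group and without any 1,2-oxazole at this position. No evidence is available on why the change has an effect of this size.

From the compounds shown here alone, whether the methyl group on the pyrazole contributes remains open, as does how the unsubstituted pyrazole, or one carrying an ethyl group, an amine or a carboxylic acid in its place, would compare with compound 4. Compound 1 has no reported result, so its side chain with the terminal primary amide cannot be set against the other groups at this position.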